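A few compounds are considered here, and "the series" means these few. Any claim that something is new, unique, unknown or untested is made for them only; others in the source may bear on it.

Measured in an ADME assay on A549 cells (Homo sapiens) for cytotoxicity, read by MTT assay, with a stated time of 24 h; on this read-out lower numbers stand for an effect already at smaller amounts and higher numbers for an effect only at larger amounts of compound:
compound 1 `COCCOCCOCCOCCOCCOCCOCC(=O)Oc1c(C(C)C)cccc1C(C)C` gives 520000 nM
compound 2 `COCCOCCOCCOCCOCCOCCOC(=O)Oc1c(C(C)C)cccc1C(C)C` gives 730000 nM
compound 3 `COCCOCCOCCOCCOCCOCCOCCOCC(=O)Oc1c(C(C)C)cccc1C(C)C` gives 520000 nM

Compound 3 stands level with compound 1 in this assay, the two together the lowest of the three numbers, and compound 2 differs from compound 3 only within the scatter. Compound 4 `COCCOCCOCCOCCOCC(=O)Oc1c(C(C)C)cccc1C(C)C` differs from compound 3 by hydrogen in place of (2-(2-methoxyethoxy)ethoxy)methyl on a saturated chain carbon bound to an oxygen on a saturated carbon. For the measured compounds named here, the one measured step bearing on this is no change at the digits printed from compound 1 to compound 3 (within the scatter), a change of the same kind at the same place, smaller and in the other direction. Compound 2, with a shorter chain, also falls within the scatter of compound 3. In this assay compound 4 is therefore expected to show a 1.1-fold higher number from compound 3 to compound 4 (0.02 log units; within the scatter), no step beyond the scatter. The estimate for compound 4 in this assay is 550000 nM, with a range from 320000 nM to 950000 nM.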

Compound 4, half-maximal effective concentration in the A549 assay: 630000 nM
Compound 4: the middle estimate sits 1.1-fold (0.06 log units) below what was measured, within the range that was stated.
By their numbers in the A549 assay, from the lowest: compounds 1, 3, 4 and 2 (each within the scatter of the next).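

In the A549 assay, hydrogen in place of (2-(2-methoxyethoxy)ethoxy)methyl at this place on the chain leaves the read-out within the scatter, with a 1.2-fold higher number from compound 3 to compound 4 (0.08 log units; within the scatter) and a 1.2-fold higher number from compound 1 to compound 4 (0.08 log units; within the scatter). In a physicochemical assay for solubility, in phosphate buffer, at pH 7.4 (a lower number here means a less soluble compound, a higher number a more soluble compound), compound 3 gives > 216000 ug/mL, which is a limit of the assay. In the physicochemical assay, compound 4 gives 1580 ug/mL. In the physicochemical assay, the same change reads as an at least 130-fold lower number from compound 3 to compound 4 (2.13 log units; beyond the scatter).

From the compounds shown here alone, the true size of that gap stays open while one end of it is a limit. Also open, going by these compounds, is how an amine or a carboxylic acid on the chain would read in either assay.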